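A few compounds are considered here, and "the series" means these few. Any claim that something is new, unique, unknown or untested is made for them only; others in the source may bear on it.

Compound 1 `OC[C@H]1O[C@@H](n2cnc3c(NCc4ccccc4)nccc32)C[C@@H]1O` gives 15% in a functional assay (Homo sapiens) for inhibition of Nucleic Acid, tested at 100 uM; on this read-out higher numbers stand for more inhibition at the one concentration tested (going by the name of the read-out) and lower numbers for less inhibition.
Compound 2 `CCNc1nccc2c1ncn2C1O[C@H](CO)[C@@H](O)[C@H]1O` gives 4% in this assay.
Compound 3 `OC[C@H]1O[C@@H](n2cnc3c(S)nccc32)C[C@@H]1O` gives 10% in this assay.

Compound 3 stands among three numbers that all lie within the scatter of one another: its nearest neighbour is compound 1, its furthest is compound 2, and neither gap is beyond the scatter. Compound 4 `OC[C@H]1O[C@@H](n2cnc3c(SCc4ccccc4)nccc32)C[C@@H]1O` differs from compound 3 by benzyl in place of hydrogen on a sulfur. Among the measured compounds shown here, one measured step bears on this change: the step of a number 5 percentage points lower from compound 1 to compound 3 (within the scatter), in which a benzyl group attached through a nitrogen was lost. That step stayed within the scatter, so the return of a benzyl group, now on the sulfur, is not expected to move the number beyond the scatter either. Compound 4 is therefore expected to give about 12% in this assay, within a range from 0% to 30%. The expected step of a number 2 percentage points higher from compound 3 to compound 4 (within the scatter) is estimated to lie within the scatter, because the step of a number 5 percentage points lower from compound 1 to compound 3 (within the scatter) did so.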

Compound 4, a percentage reported as inhibition, at one concentration (the size of the read-out at that concentration, not a potency): 18%
Estimate against measurement, compound 4: 6 percentage points below, and the stated range covers the measured number.
By their numbers in this assay, from the lowest: compounds 2, 3, 1 and 4 (each within the scatter of the next, the first and the last beyond it).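

In this assay, the benzyl group on the sulfur of the thiol compound gives a step that stays within the scatter: a number 8 percentage points higher from compound 3 to compound 4 (within the scatter). Replacing the nitrogen that carries the benzyl group with sulfur, benzylsulfanyl in place of benzylamino on an aromatic carbon, also stays within the scatter: a number 3 percentage points higher from compound 1 to compound 4 (within the scatter). On the shared core, therefore, the read-out does not separate sulfanyl, benzylamino and benzylsulfanyl at this position, and neither the benzyl group nor the atom carrying it is seen to matter beyond the scatter.

No measurement in hand explains these numbers. On these data alone, whether an amine, a carboxylic acid or a longer alkyl chain on the sulfur would give a number beyond the scatter remains open.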